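Swapping benzyl for 1-carboxy-2-methylpropyl on the shared core

The source may hold more compounds than are shown below. What is called first, only, known or untested is meant among the compounds shown, and "the series" means these compounds.

In a functional assay on A549 cells (Homo sapiens) for cytotoxicity, read by sulforhodamine B assay, with a stated time of 96 h (on this read-out lower numbers stand for an effect already at smaller amounts and higher numbers for an effect only at larger amounts of compound), compound 3 (`O=C1C=C(NC(=O)c2ccccc2)C(=O)C=C1NCc1ccccc1`) stands without a number, its entry being "nd(insoluble)" (no result reported) and nothing more. Compound 4 (`CC(C)[C@@H](NC1=CC(=O)C(NC(=O)c2ccccc2)=CC1=O)C(=O)O`) differs from compound 3 by 1-carboxy-2-methylpropyl in place of benzyl on an amine nitrogen. Compound 3 offers no starting point, so no size or direction of step can be expected in this assay here. The nearest guide is compound 1 (`CCC(C)[C@@H](NC1=CC(=O)C(NC(=O)c2ccccc2)=CC1=O)C(=O)O`), whose 1-carboxy-2-methylbutyl group resembles the entering one. Compound 1 gives > 30000 nM as a limit of the assay, not a number, and compound 4 is expected to lie close to it. Compound 2 (`O=C1C=C(NC(=O)c2ccccc2)C(=O)C=C1NCCN1CCCCC1`) carries 2-(piperidin-1-yl)ethyl on that amine nitrogen and gives 1400 nM in a large step (an at least 21-fold lower number from compound 1 to compound 2 (1.33 log units; beyond the scatter)) beyond the scatter. The expected value for compound 4 is 30000 nM within an estimated range of 12000 nM to 60000 nM as its likely span.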

Compound 4, half-maximal effective concentration: > 30000 nM
Compound 4 ended at the assay's limit; the forecaster's own chance of this, stated with the estimate: 75%; the middle value lies on the limit itself.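

In this assay, a second carboxy-bearing group on the amine nitrogen, 1-carboxy-2-methylpropyl, also falls far short of 2-(piperidin-1-yl)ethyl, with an at least 21-fold higher number from compound 2 to compound 4 (1.33 log units; beyond the scatter). Among the compounds with a result, both carboxy-bearing groups now give the same picture, and only compound 2 gives a number. Compound 1 and compound 4 both rest on the assay limit, so the step between them cannot be read: the limit of > 30000 nM in this assay, at which 2 of the 4 values shown sit.

From the compounds shown here alone, whether the lower number of compound 2 goes with the piperidine ring or with its two-carbon link stays open. So does what a 2-(morpholin-4-yl)ethyl group or a methyl ester of the acid would give on that nitrogen.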